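Thiophen-3-yl to Furan-2-yl: a Step Not Yet Measured

The source may hold more compounds than are shown below. What is called first, only, known or untested is meant among the compounds shown, and "the series" means these compounds.

Measured so far in an assay on isolated protein for inhibition of DNA topoisomerase 1 (Homo sapiens), with a stated time of 30 min, tested at 100 uM; on this read-out lower numbers stand for a weaker effect and higher numbers for a stronger effect at the one concentration tested:
- compound 1, `Oc1ccc(-c2cc(-c3ccsc3)cc(-c3cccc(O)c3)n2)cc1`, gives 17.1%
- compound 2, `Oc1ccc(-c2cc(-c3ccsc3)cc(-c3ccc(O)cc3)n2)cc1`, gives 61.7%

Compound 1 stands lowest of the two numbers. Going by the values given here, its only measured neighbour is compound 2, and the step of a number 44.6 percentage points higher from compound 1 to compound 2 (beyond the scatter) is large and beyond the scatter. That step, however, moves the hydroxyl on one of the phenyl rings; it says nothing about the five-membered ring opposite the ring nitrogen.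

The compound now in question is compound 3, `Oc1ccc(-c2cc(-c3ccco3)cc(-c3cccc(O)c3)n2)cc1`. It differs from compound 1 by a single change: furan-2-yl in place of thiophen-3-yl on an aromatic carbon. Both groups are five-membered aromatic rings with one hetero atom and one hydrogen-bond acceptor, so the change is a small one in size.

Among the compounds with values here, no measured step touches this position, so there is nothing in the data to predict a direction. The most defensible expectation is therefore a step of a number 2.9 percentage points higher from compound 1 to compound 3 (within the scatter), that is, none beyond the scatter, with compound 1 as the anchor. Compound 3 is thus expected to give about 20% in this assay, within a range from 5% to 45%.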

Compound 3, a percentage reported as inhibition, at one concentration (the size of the read-out at that concentration, not a potency): 100%
Compound 3: middle estimate off by 80 percentage points, on the low side, and the stated range ends below it.
By their numbers in this assay, from the lowest: compound 1; then compound 2; then compound 3.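

In this assay, the five-membered ring opposite the ring nitrogen turns out to matter a great deal: furan-2-yl in place of thiophen-3-yl gives a number 82.9 percentage points higher from compound 1 to compound 3 (beyond the scatter). Until now, only the hydroxyl on a phenyl ring had been seen to move the read-out, and this result shows that a second part of compound 1 can do so too, even though the two rings match in heavy-atom count, ring size and hydrogen-bond acceptor count, so those counts alone do not predict the outcome here. No measurement shown here explains why this exchange has so large an effect.

The exchange alters two things at once, the hetero atom (oxygen for sulfur) and the ring's point of attachment, and thiophen-2-yl or furan-3-yl at this position would be needed to tell their contributions apart. On these data alone, it also remains open whether furan-2-yl gives a similar step in the core of compound 2, and how a six-membered ring such as phenyl or pyridinyl would fare at this position.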